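A few compounds are considered here, and "the series" means these few. Any claim that something is new, unique, unknown or untested is made for them only; others in the source may bear on it.

In an assay on CHO-K1 cells for displacement of a labelled ligand from prostaglandin E2 receptor EP1 subtype (Homo sapiens) (a higher number here means a weaker inhibitor, a lower number a stronger inhibitor), compound 3 `Cc1cc(NC(=O)CC(C)(C)C)nn1Cc1cc(Cl)ccc1OCc1ccccc1` gives 10 nM, the lowest of the three numbers recorded. Compound 1 `Cc1cc(C(=O)Nc2ccc(F)cc2)nn1Cc1cc(Cl)ccc1OCc1ccccc1` gives 79.4 nM in this assay, and compound 2 `Cc1cc(C(=O)Nc2ccccn2)nn1Cc1cc(Cl)ccc1OCc1ccccc1` gives 126 nM. The step of a 1.6-fold higher number from compound 1 to compound 2 (0.20 log units; within the scatter) stays within the scatter, whereas a 7.9-fold lower number from compound 1 to compound 3 (0.90 log units; beyond the scatter) and a 13-fold lower number from compound 2 to compound 3 (1.10 log units; beyond the scatter) both go beyond it.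

Compound 4 `Cc1cc(NC(=O)OCc2ccccn2)nn1Cc1cc(Cl)ccc1OCc1ccccc1` differs from compound 3 only on the acyl side: (pyridin-2-yl)methoxy in place of neopentyl on a carbonyl carbon. Within the data shown here, none of the measured steps touches this carbonyl carbon; the two informative steps, from compound 1 and compound 2 to compound 3, changed the direction of the amide together with its substituent, so they bear on compound 4 only indirectly. The two aryl-bearing amides in compound 1 and compound 2 both sit well above compound 3, and the entering group brings back an aromatic ring. Compound 4 is therefore expected to lose some ground against compound 3, an expected step of a 3.0-fold higher number from compound 3 to compound 4 (0.48 log units; beyond the scatter). Compound 4 is estimated at 30 nM, within 8 nM to 120 nM.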

Compound 4, half-maximal inhibitory concentration: 79.4 nM
Beside the measured number, compound 4's estimate is 2.6-fold (0.42 log units) below it; low and high end bracket the measured number.
By their numbers in this assay, from the lowest: compound 3; then compounds 1, 4 and 2 (each within the scatter of the next).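

At this carbonyl carbon, (pyridin-2-yl)methoxy in place of neopentyl gives a 7.9-fold higher number from compound 3 to compound 4 (0.90 log units; beyond the scatter) in this assay, so the position responds to what it carries, and the low number of compound 3 does not follow from the amide-type nitrogen on the aromatic carbon alone. Compound 4 keeps that nitrogen yet stands level with the two compounds carrying a carbamoyl group on the aromatic carbon. The steps show a 1.6-fold lower number from compound 2 to compound 4 (0.20 log units; within the scatter) and no change at the digits printed from compound 1 to compound 4 (within the scatter).

No evidence here accounts for the loss from neopentyl to (pyridin-2-yl)methoxy. The compounds shown leave open whether that loss goes with the pyridine ring or with the oxygen on the carbonyl carbon, which a tert-butoxy group at the same place could separate.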